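This account rests on a few compounds, and the source may have more. Where it says the series, first, only, none or still open, it means among the compounds named here.

In a functional assay on L1210 cells (Mus musculus) for inhibition, read by MTT assay, with a stated time of 72 h (on this read-out lower numbers stand for stronger inhibition and higher numbers for weaker inhibition), three compounds on a shared core have been measured: compound 1 (`COc1cc(NC(C)CCCNC(=O)NNC(=O)Nc2ccc(F)cc2)c2ncccc2c1`), compound 2 (`COc1cc(NC(C)CCCNC(=O)NNC(=O)Nc2cccc(C(F)(F)F)c2)c2ncccc2c1`) and compound 3 (`COc1cc(NC(C)CCCNC(=O)NNC(=O)Nc2cccc(Cl)c2)c2ncccc2c1`). Compound 1 gives 104000 nM and compound 3 gives 27000 nM while compound 2 gives 4000 nM as the lowest number of the three, beyond the scatter of both others. Compound 4 (`COc1cc(NC(C)CCCNC(=O)NNC(=O)Nc2cc(C(F)(F)F)cc(C(F)(F)F)c2)c2ncccc2c1`) departs from compound 2 by one change (trifluoromethyl in place of hydrogen on an aromatic carbon), trifluoromethyl in place of hydrogen on an aromatic carbon, meta to a trifluoromethyl group. Going by the values given here, no measured step adds a group in this way, so the evidence is indirect. The large step (a 26-fold lower number from compound 1 to compound 2 (1.41 log units; beyond the scatter)) brought in 3-(trifluoromethyl)phenyl in place of 4-fluorophenyl, and the modest one (a 3.9-fold lower number from compound 1 to compound 3 (0.59 log units; beyond the scatter)) brought in 3-chlorophenyl instead. Another modest step (a 6.8-fold higher number from compound 2 to compound 3 (0.83 log units; beyond the scatter)) put chloro in place of trifluoromethyl on an aromatic carbon. Among these three compounds the lowest number goes with trifluoromethyl and none goes against that, but they show only a direction, not the size of adding a second such group. A modest move toward a lower number is therefore expected, with the estimated step (a 2.7-fold lower number from compound 2 to compound 4 (0.43 log units; beyond the scatter)) in that direction. For compound 4 the expected value is 1500 nM with an estimated range from 300 nM to 7000 nM on this read-out.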

Compound 4, half-maximal inhibitory concentration: 18000 nM
Compound 4: middle estimate off by 12-fold (1.08 log units), on the low side; measured number above the stated range.
By their numbers in this assay, from the lowest: compound 2; then compounds 4 and 3 (each within the scatter of the next); then compound 1.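

In this assay, trifluoromethyl in place of hydrogen on an aromatic carbon, meta to a trifluoromethyl group, gave a 4.5-fold higher number from compound 2 to compound 4 (0.65 log units; beyond the scatter) and so moved the number up, not down. Going by these compounds alone, the earlier compounds showed only one group swapped for another on this ring, with the lowest number going with a single trifluoromethyl group, whereas this step adds a group to a ring that already carries one. It shows that, at this position, a second trifluoromethyl group does not extend the gain that went with the first, so more of this group did not give a lower number here. No measurement among the data shown bears on the reason for this rise. As far as these compounds go, whether a smaller group at this same place, such as a nitrile or a methyl group, would also raise the number remains open. Also open, from the compounds shown here alone, is whether an amine or a hydroxyl group there would move it the other way, which would help show whether the rise belongs to trifluoromethyl itself or to any group entering at this position.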